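Azetidinyl in place of anilino on the shared core

This account rests on a few compounds, and the source may have more. Where it says the series, first, only, none or still open, it means among the compounds named here.

Measured compounds:
compound 1 `COc1cccc(NC2=CC(=O)c3c(nc4n3[C@H]3OC[C@@H](O)[C@H]3OC4)C2=O)c1` 1790 nM
compound 2 `O=C1C=C(Nc2ccccc2)C(=O)c2c1nc1n2[C@H]2OC[C@@H](O)[C@H]2OC1` 1730 nM
compound 3 `CCOc1ccccc1NC1=CC(=O)c2nc3n(c2C1=O)[C@H]1OC[C@@H](O)[C@H]1OC3` 2450 nM

All three were tested in a functional assay on MGC-803 cells (Homo sapiens) for inhibition, read by sulforhodamine B assay; a higher number here means a weaker inhibitor, a lower number a stronger inhibitor. Compound 1 gives the second highest of the three numbers; its nearest neighbour is compound 2, and its furthest is compound 3, and both gaps lie within the scatter, so the three stand together. Among the compounds with values here, the only single-point step among them, a 1.4-fold higher number from compound 2 to compound 3 (0.15 log units; within the scatter), is also within the scatter.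

Compound 4 `O=C1C(N2CCC2)=CC(=O)c2c1nc1n2[C@H]2OC[C@@H](O)[C@H]2OC1` is not yet measured. Its difference from compound 1 is azetidin-1-yl in place of (3-methoxyphenyl)amino on a double-bonded ring carbon. Within the data shown here, no measured step touches this position: the one recorded step changes the aromatic ring that here leaves altogether. The data therefore give no direction for this change, only the observation that the three anilino compounds cluster closely. The account expects the number for compound 4 to lie near that cluster, with a wide range on either side, so the step of a 1.7-fold higher number from compound 1 to compound 4 (0.22 log units; within the scatter) is an estimate without direct support. Compound 4 is estimated at 3000 nM, between 700 nM and 13000 nM.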

Compound 4, half-maximal inhibitory concentration: > 16000 nM
Compound 4: a limit, no number; the forecaster's own chance of this, stated with the estimate: 10%; middle value at least 5.3-fold (0.72 log units) from the limit.
By their numbers in this assay, from the lowest: compounds 2, 1 and 3 (each within the scatter of the next). At a limit, above all of these: compound 4.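

In this assay compound 4 gives > 16000 nM, which is a limit and not a number. Azetidin-1-yl in place of (3-methoxyphenyl)amino on the double-bonded ring carbon gives an at least 8.9-fold higher number from compound 1 to compound 4 (0.95 log units; beyond the scatter), so this position, unlike the aromatic ring changed in the only earlier step, a 1.4-fold higher number from compound 2 to compound 3 (0.15 log units; within the scatter), is shown to matter for the read-out. The size of this step is known from one side only and rests on a single compound at the limit: the limit of > 16000 nM in this assay, at which 1 of the 4 values shown sits.

The compounds shown leave open whether the step follows from the loss of the anilino group as a whole or from the azetidine ring that enters. Going by these compounds, a benzylamino, dimethylamino or piperidin-1-yl group on the same carbon could separate these two readings, and how far compound 4 lies past its limit remains unknown.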